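A few compounds are considered here, and "the series" means these few. Any claim that something is new, unique, unknown or untested is made for them only; others in the source may bear on it.

Measured so far:
compound 1 `O=C(Nc1cccnc1)c1ccncc1` — 39%
compound 2 `O=C(Nc1cccnc1)c1cncc(Br)c1` — 29%
compound 3 `O=C(Nc1cccnc1)c1ccc(OC(F)(F)F)cc1` — 3%

In an assay on V79 cells for inhibition of cytochrome P450 11B2, mitochondrial (Homo sapiens), tested at 500 nM (a lower number here means less inhibition, a higher number more inhibition at the concentration tested (going by the name of the read-out)), compound 3 stands lowest of the three numbers; compound 2 gives a higher number and compound 1 a higher one still, each gap beyond the scatter. Compound 4 `Cc1ccc(C(=O)Nc2cccnc2)cc1` is not yet measured. It differs from compound 3 by methyl in place of trifluoromethoxy on an aromatic carbon. Among the measured compounds shown here, no pair of measured compounds shows this change, so the direction rests only on compound 3 holding the lowest number while compounds 1 and 2 sit higher. A modest rise is expected from compound 3 to compound 4 a number 12 percentage points higher from compound 3 to compound 4 (beyond the scatter), though staying within the scatter cannot be ruled out. For compound 4 the estimate is 15%, with a range from 2% to 40%.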

Compound 4, a percentage reported as inhibition, at one concentration (the size of the read-out at that concentration, not a potency): 25%
For compound 4 the middle estimate is 10 percentage points below the measured one; measured number inside the range.
By their numbers in this assay, from the lowest: compound 3; then compounds 4, 2 and 1 (each within the scatter of the next, the first and the last beyond it).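

In this assay, methyl in place of trifluoromethoxy on an aromatic carbon, para to a group of 9 heavy atoms, gives a number 22 percentage points higher from compound 3 to compound 4 (beyond the scatter). Among the compounds shown here, this is the first step that isolates one place, and it shows that the number responds to the group held at this position. No evidence at hand accounts for the step.

Two groups at one position give no trend. Going by these compounds, whether an amine, a carboxylic acid or a longer chain there would land nearer compound 3 or compound 4 remains open.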